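Cytotoxicity notes on two fluorophenyl ether variants

This account rests on a few compounds, and the source may have more. Where it says the series, first, only, none or still open, it means among the compounds named here.

Compound 1 `CCOC(=O)c1cc(-c2cccc(OCc3cccc(F)c3)c2)on1` was tested in an ADME assay on Vero cells (Chlorocebus sabaeus) for cytotoxicity, with a stated time of 72 h; a lower number here means a stronger inhibitor, a higher number a weaker inhibitor. For compound 1 the result is a limit of the assay, > 128000 nM, which is the limit of > 128000 nM in this assay, at which 1 of the 2 values shown sits. Compound 2 `CCOC(=O)c1cc(-c2cccc(OCc3ccc(F)cc3)c2)on1` has no number in this assay; its entry reads "not determined" (no result reported). Among the compounds with values here, compound 2 therefore stands nowhere on the scale so far, and the only value shown is the limit of compound 1. Compound 3 `CCOC(=O)c1cc(-c2cccc(OCc3cccc(F)c3F)c2)on1` differs from compound 2 by 2,3-difluorophenyl in place of 4-fluorophenyl on a saturated chain carbon bound to an oxygen on an aromatic ring. Within the data shown here, no measured step exists in this assay, so no shift beyond the scatter is expected from this change. Compound 3 is expected to give about 128000 nM, within 60000 nM to 300000 nM, in this assay.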

Compound 3, half-maximal inhibitory concentration: > 128000 nM
Compound 3 gave a limit, no number; the forecaster's own chance of this, stated with the estimate: 70%; the middle value sits exactly at the limit.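

No step can be read between compound 1 and compound 3, whose results in this assay are both limits, not numbers. Left open is whether fluoro in place of hydrogen on an aromatic carbon shifts cytotoxicity at all.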